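Replacing 2,4,6-trifluorophenyl with 2-phenylethenyl in compound 3

This account rests on a few compounds, and the source may have more. Where it says the series, first, only, none or still open, it means among the compounds named here.

- Compound 1 `COc1cc(C(=O)c2cn(-c3ccccc3)cc2-c2ccccc2C)cc(OC)c1OC` gives 190 nM
- Compound 2 `COc1cc(C(=O)c2cn(-c3ccccc3)cc2-c2cccc(Cl)c2)cc(OC)c1OC` gives 540 nM
- Compound 3 `COc1cc(C(=O)c2cn(-c3ccccc3)cc2-c2c(F)cc(F)cc2F)cc(OC)c1OC` gives 180 nM

In a functional assay on MCF7 cells (Homo sapiens) for cytotoxicity, read by MTT assay, with a stated time of 96 h (on this read-out lower numbers stand for stronger inhibition and higher numbers for weaker inhibition), compound 3 sits level with compound 1 at the low end of these numbers, and a 1.1-fold lower number from compound 1 to compound 3 (0.02 log units; within the scatter) marks no real difference between them. Compound 2 stands apart, with a 2.8-fold higher number from compound 1 to compound 2 (0.45 log units; beyond the scatter) and a 3.0-fold lower number from compound 2 to compound 3 (0.48 log units; beyond the scatter) as steps of modest size.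

The next compound is compound 4 `COc1cc(C(=O)c2cn(-c3ccccc3)cc2/C=C/c2ccccc2)cc(OC)c1OC`, and the change that leads to it is 2-phenylethenyl in place of 2,4,6-trifluorophenyl on an aromatic carbon in the same place on the shared core. The entering group keeps one six-membered aromatic ring of carbon only, as the leaving group does, but adds 1 double bond outside aromatic rings.

For the measured compounds named here, no measured step involves such a group. The three steps above only exchange one substituted phenyl for another, so they offer a rough guide to size and nothing more. With compound 3 at 180 nM in the low group of this small set, a modest rise in this assay is expected, though the uncertainty is wide. The step expected is a 1.9-fold higher number from compound 3 to compound 4 (0.29 log units; within the scatter) by this estimate. For compound 4 the estimated value is 350 nM with 100 nM to 1200 nM as the expected range.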

Compound 4, half-maximal inhibitory concentration: 2200 nM
Compound 4: the middle estimate sits 6.3-fold (0.80 log units) below what was measured, and the stated range ends below it.
By their numbers in this assay, from the lowest: compounds 3 and 1 (each within the scatter of the next); then compound 2; then compound 4.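

In this assay, placing 2-phenylethenyl at this position of the shared core gives a 12-fold higher number from compound 3 to compound 4 (1.09 log units; beyond the scatter) and a 12-fold higher number from compound 1 to compound 4 (1.06 log units; beyond the scatter), both larger than any step seen when one substituted phenyl was exchanged for another. Even from the highest of the earlier numbers, the same kind of change gives a 4.1-fold higher number from compound 2 to compound 4 (0.61 log units; beyond the scatter), so all three compounds with a phenyl ring bonded straight to this aromatic carbon have lower numbers than the compound whose ring is carried on a double bond, and none of the shown compounds goes against this. So the position accepts some changes to the substituents on that phenyl ring with modest shifts at most, yet it does not accept this change of group without a large rise, and no measurement shown here bears on the cause of that rise.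

The compounds shown do not separate the double bond from the greater distance of the ring, a question that 2-phenylethyl, the same group without the double bond, or a benzyl group could help to answer. Also open, going by these compounds, is whether a group with no ring at all, such as a short alkyl chain, or a ring containing nitrogen, such as pyridyl, would stay near compound 3 at 180 nM in this assay.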